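Methoxy for tert-butyl on the benzyl ring of compound 1

The source may hold more compounds than are shown below. What is called first, only, known or untested is meant among the compounds shown, and "the series" means these compounds.

Compound 1 `CC(C)(C)c1ccc(CNCCCNS(=O)(=O)c2cc(C(F)(F)F)cc(C(F)(F)F)c2)cc1` gives 3200 nM in a toxicity assay on MCF-10A cells (Homo sapiens) for inhibition, read by MTT assay, with a stated time of 72 h (on this read-out lower numbers stand for stronger inhibition of growth and higher numbers for weaker inhibition of growth), the second highest of the three numbers. Compound 2 `O=S(=O)(NCCCNCc1ccc(Cl)c(Cl)c1)c1cc(C(F)(F)F)cc(C(F)(F)F)c1` gives 3000 nM, and a 1.1-fold lower number from compound 1 to compound 2 (0.03 log units; within the scatter). Compound 3 `O=S(=O)(NCCCNCc1ccccc1)c1cc(C(F)(F)F)cc(C(F)(F)F)c1` gives 13000 nM, so a 4.1-fold higher number from compound 1 to compound 3 (0.61 log units; beyond the scatter), and a 4.3-fold higher number from compound 2 to compound 3 (0.64 log units; beyond the scatter). Compound 4 `COc1ccc(CNCCCNS(=O)(=O)c2cc(C(F)(F)F)cc(C(F)(F)F)c2)cc1` differs from compound 1 in one place: methoxy in place of tert-butyl on an aromatic carbon. The step from compound 1 to compound 3 bears most directly, since it removes the tert-butyl altogether and the number rose modestly. Compound 4 keeps a smaller group at that place, so a rise smaller than that of compound 3 is expected, a 2.0-fold higher number from compound 1 to compound 4 (0.31 log units; beyond the scatter). For compound 4 the estimate is 6500 nM, with a range from 2800 nM to 15000 nM.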

Compound 4, concentration for 50% growth inhibition: 3100 nM
Beside the measured number, compound 4's estimate is 2.1-fold (0.32 log units) above it, within the range that was stated.
By their numbers in this assay, from the lowest: compounds 2, 4 and 1 (each within the scatter of the next); then compound 3.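

In this assay, methoxy on this aromatic carbon leaves the number level with tert-butyl (a 1.0-fold lower number from compound 1 to compound 4 (0.01 log units; within the scatter)), yet it still separates clearly from hydrogen (a 4.2-fold lower number from compound 3 to compound 4 (0.62 log units; beyond the scatter)), so tert-butyl itself is not needed here. The 4-methoxyphenyl compound also matches the 3,4-dichlorophenyl compound (a 1.0-fold higher number from compound 2 to compound 4 (0.01 log units; within the scatter)), which leaves compound 3, without any group on the ring, as the only one apart. No measurement at hand explains this.

From the compounds shown here alone, whether a hydroxyl or an amine on this aromatic carbon would stay with compounds 1, 2 and 4 or fall with compound 3 remains open. So does the effect of a longer chain between the two nitrogens.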